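Swapping diethylamino for propyl on a shared core

The source may hold more compounds than are shown below. What is called first, only, known or untested is meant among the compounds shown, and "the series" means these compounds.

Measured so far in a functional assay on the whole organism with Mus musculus as the target, in the rotarod test; on this read-out higher numbers stand for an effect only at larger amounts of compound and lower numbers for an effect already at smaller amounts:
compound 1 `CCC(=O)NCC(=O)N(C)c1ccc(Cl)cc1C(=O)c1ccccc1Cl`: 36 mg/kg
compound 2 `CCN(CC)CC(=O)NCC(=O)N(C)c1ccc(Cl)cc1C(=O)c1ccccc1Cl`: 34 mg/kg

For the measured compounds named here, compound 2 stands level with its one measured neighbour, since the two are separated only by a 1.1-fold lower number from compound 1 to compound 2 (0.02 log units; within the scatter). Neither compound stands out on these numbers.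

The next compound is compound 3 `CCCCC(=O)NCC(=O)N(C)c1ccc(Cl)cc1C(=O)c1ccccc1Cl`. The change that leads to it is propyl in place of diethylamino on a saturated chain carbon bound to a carbonyl carbon. In words, propyl takes the place of diethylamino on a saturated chain carbon bound to a carbonyl carbon.

Going by the values given here, only one measured step bears on this place. That step, a 1.1-fold lower number from compound 1 to compound 2 (0.02 log units; within the scatter), put diethylamino in place of methyl on the same carbon and stayed within the scatter. Propyl itself has not been measured, and a single step is thin evidence, so the range has to stay wide. On this basis, no change beyond the scatter is expected in this assay. The expected step is a 1.0-fold higher number from compound 2 to compound 3 (0.01 log units; within the scatter). For compound 3 the estimated value is 35 mg/kg, with an expected range from 15 mg/kg to 80 mg/kg.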

Compound 3, dose for half-maximal effect: 90 mg/kg
Compound 3: middle estimate off by 2.6-fold (0.41 log units), on the low side; measured number above the stated range.
By their numbers in this assay, from the lowest: compounds 2 and 1 (each within the scatter of the next); then compound 3.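

In this assay this position turns out not to be indifferent to what it carries: putting propyl in place of diethylamino gives a 2.6-fold higher number from compound 2 to compound 3 (0.42 log units; beyond the scatter) and so moves the number beyond the scatter, which the earlier step between compound 1 and compound 2 did not do. Compared with the shorter chain, ethyl in place of hydrogen on a saturated chain carbon, two bonds along the chain from a carbonyl carbon, gives a 2.5-fold higher number from compound 1 to compound 3 (0.40 log units; beyond the scatter) and likewise means that a larger amount is needed for the effect. Of the three compounds, then, compound 3 with its butyl group on the carbonyl stands apart, while compound 1 and compound 2 remain level with each other, and nothing measured here gives a reason for this difference.

On these data alone, three compounds cannot separate the effect of chain length from the loss of the diethylamino nitrogen, so it remains open whether a longer chain such as hexyl would raise the number further. As far as these compounds go, it is equally open whether another amine, such as piperidine, would keep the number level with compound 2.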